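Changing the Ring Attached to the Core Nitrogen

This account rests on a few compounds, and the source may have more. Where it says the series, first, only, none or still open, it means among the compounds named here.

Three compounds share one core and differ only in the ring that hangs from one of its nitrogen atoms. Compound 1 `Oc1cc(C(F)(F)F)ccc1-c1nc(-c2ccccc2O)n(-c2ccc(Cl)cc2)n1` gives 68% in a functional assay on PC-12 cells (Rattus norvegicus) for cytotoxicity, read by MTT assay, with stated times of 2 h and 24 h, tested at 1 uM; a higher number here means a stronger effect of the compound at the concentration tested, a lower number a weaker effect. Compound 2 `Oc1cc(C(F)(F)F)ccc1-c1nc(-c2ccccc2O)n(-c2ccc(C(F)(F)F)cc2)n1` gives 70.7% in this assay, and compound 3 `COc1ccc(-n2nc(-c3ccc(C(F)(F)F)cc3O)nc2-c2ccccc2O)cc1` gives 69%. Among these three numbers compound 3 holds the second highest, but all sit close together: the step of a number 1 percentage points higher from compound 1 to compound 3 (within the scatter), the step of a number 1.7 percentage points lower from compound 2 to compound 3 (within the scatter) and the step of a number 2.7 percentage points higher from compound 1 to compound 2 (within the scatter) are each within the scatter, so the three read as one level.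

Compound 4 `Oc1cc(C(F)(F)F)ccc1-c1nc(-c2ccccc2O)n(-c2ccccc2F)n1` alters the same ring again, this time (2-fluorophenyl in place of 4-methoxyphenyl on an aromatic nitrogen). Among the measured compounds shown here, the change differs from the measured steps, which swapped only one group on that ring and kept its position, whereas here the whole ring is exchanged, including the position of the single group on it. For the measured compounds named here, no measured pair reports such a swap. The three steps seen so far stayed within the scatter, so a step in this assay no larger than that is expected here, with no direction favoured, given as a number 1 percentage points lower from compound 3 to compound 4 (within the scatter). Compound 4 is therefore estimated at 68%, with a range from 56% to 80%.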

Compound 4, a percentage reported as activity, at one concentration (the size of the read-out at that concentration, not a potency): 63.4%
Compound 4: middle estimate off by 4.6 percentage points, on the high side; the measured number falls inside the stated range.
By their numbers in this assay, from the lowest: compounds 4, 1, 3 and 2 (each within the scatter of the next).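

In this assay, the position on the aromatic nitrogen tolerates more than a swap of one group at a fixed place on the ring: going to 2-fluorophenyl changes both the group and where it sits, and compound 4 still reads at the level of the other three. The steps are a number 5.6 percentage points lower from compound 3 to compound 4 (within the scatter) and a number 7.3 percentage points lower from compound 2 to compound 4 (within the scatter) and also a number 4.6 percentage points lower from compound 1 to compound 4 (within the scatter) and, although each is larger in size than any step among the first three compounds, none leaves the scatter. So among these four compounds, neither the choice among these single groups nor the move to 2-fluorophenyl gives a separable difference, and no measured evidence bears on why this reading holds.

Because the group and its place on the ring change together in compound 4, these compounds cannot separate the two, and a comparison with 4-fluorophenyl or with 2-methoxyphenyl would be needed to do so. From the compounds shown here alone, all four also keep a substituted phenyl ring on that nitrogen, so it remains open how the read-out would respond to a ring bearing an amine or a carboxylic acid, or to a longer alkyl chain in place of the ring.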